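Compound 4: losing the phenyl group

This account rests on a few compounds, and the source may have more. Where it says the series, first, only, none or still open, it means among the compounds named here.

Measured in a toxicity assay on THP-1 cells (Homo sapiens) for inhibition (a lower number here means that less compound is tolerated, a higher number that more compound is tolerated), so far
compound 1 (`Cc1ccc(-c2cnc(NC(=O)c3ccc(F)cc3)n2C)cc1`): 60000 nM
compound 2 (`COc1ccc(-c2cnc(NC(=O)c3ccc(F)cc3)n2-c2ccccc2)cc1`): 8800 nM
compound 3 (`Cc1cccc(-c2cnc(NC(=O)c3ccc(F)cc3)n2C)c1`): > 100000 nM (a limit of the assay, not a number)

Compound 2 (8800 nM) gives the lower of the two true numbers, and compound 1 (60000 nM) lies higher by a gap beyond the scatter. Going from compound 2 to compound 4 (`COc1ccc(-c2cnc(NC(=O)c3ccc(F)cc3)[nH]2)cc1`), not yet measured, puts hydrogen in place of phenyl on an aromatic nitrogen. Within the data shown here, no measured step covers this change. Among the measured compounds shown here, the one step available (an at least 1.6-fold higher number from compound 1 to compound 3 (0.22 log units; that floor lies within the scatter)) concerns another place, its floor lies within the scatter, and it sets no size here. Indirect support comes from compound 1 (60000 nM), which carries methyl on that nitrogen but also differs from compound 2 in a second place. Its higher number suggests a rise once phenyl leaves. The expected step is a 4.5-fold higher number from compound 2 to compound 4 (0.66 log units; beyond the scatter) in this assay, towards a higher number and with wide uncertainty. Compound 4 is estimated at 40000 nM (expected range 14000 nM to 100000 nM).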

Compound 4, half-maximal cytotoxic concentration: > 100000 nM
Compound 4 ended at the assay's limit; the forecaster's own chance of this, stated with the estimate: 25%; at least 2.5-fold (0.39 log units) between middle value and limit.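

In this assay, the aromatic nitrogen now has a direct reading: hydrogen in place of phenyl gives an at least 11-fold higher number from compound 2 to compound 4 (1.05 log units; beyond the scatter) with the 4-methoxyphenyl group unchanged. The earlier compounds shown here offered only compound 1 at this nitrogen, and it differs from compound 2 in a second place as well, so the nitrogen substituent could not be read alone. Compound 4 stands at a limit of the assay, not a number, which leaves the step as a floor with its full size unread: the limit of > 100000 nM in this assay, at which 2 of the 4 values shown sit.

This change rests on a single pair, and methyl on that nitrogen has no one-place comparison with compound 2 or compound 4. Open too, going by these compounds, is whether a benzyl group, a longer chain such as propyl or a chain ending in an amine on that nitrogen would stay near compound 2 (8800 nM) or move towards compound 4.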